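Furan-2-yl Ethyl in Place of Propyl on the Urea Nitrogen

The compounds below may be only part of what the source reports. "The series", "measured", "known", "first", "only" and "open" are said of these compounds alone.

Going by the values given here, compound 1 `CCCNC(=O)/N=C(\N)NCCCc1sc(N)nc1C` gives 170 nM in a functional assay on HEK293T cells for agonist activity at histamine H2 receptor (Homo sapiens), read by beta-arrestin recruitment (on this read-out lower numbers stand for an effect already at smaller amounts and higher numbers for an effect only at larger amounts of compound), the lower of the two numbers measured so far, while compound 2 `Cc1nc(N)sc1CCCN/C(N)=N/C(=O)NCC(C)CCCc1ccccc1` gives 2510 nM. Compound 3 `Cc1nc(N)sc1CCCN/C(N)=N/C(=O)NC(C)c1ccco1` carries 1-(furan-2-yl)ethyl in place of propyl on an amide-type nitrogen. Among the compounds with values here, the only measured step, a 15-fold higher number from compound 1 to compound 2 (1.17 log units; beyond the scatter), sits at a different place but likewise brings an aromatic ring into the chain, and it went beyond the scatter. Within the data shown here, no measured step alters the group on the amide-type nitrogen itself. A moderate rise is therefore expected for compound 3, a 2.4-fold higher number from compound 1 to compound 3 (0.37 log units; beyond the scatter), giving an estimated 400 nM within a range of 120 nM to 1300 nM.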

Compound 3, half-maximal effective concentration: 234 nM
The estimate for compound 3 lay 1.7-fold (0.23 log units) above the measured number, and the stated range covers the measured number.
By their numbers in this assay, from the lowest: compounds 1 and 3 (each within the scatter of the next); then compound 2.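

On the amide-type nitrogen, 1-(furan-2-yl)ethyl in place of propyl gives a 1.4-fold higher number from compound 1 to compound 3 (0.14 log units; within the scatter) in this assay. Going by these compounds alone, this is the first reading of the group at this position, and it shows that a group carrying a five-membered aromatic ring can stand there with compound 3 within the scatter of compound 1. Nothing given here accounts for this result. As far as these compounds go, whether a benzyl group or a longer chain such as hexyl would read alike on this nitrogen stays open. So does the part played by the methyl of the 1-(furan-2-yl)ethyl group.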